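The source may report more compounds than this note shows. Statements on the series, on what has been measured and on what is new or still open speak of the compounds shown alone.

Compound 1 `CCCCc1ccc(-c2cc(N3CCC(CNS(N)(=O)=O)CC3)ncn2)cc1`: 21800 nM
Compound 2 `CCOC(=O)c1ccc(-c2cc(N3CCC(CNS(N)(=O)=O)CC3)ncn2)cc1`: 4100 nM
Compound 3 `CCCCc1ccc(-c2cc(N3CCC(CCNS(N)(=O)=O)CC3)ncn2)cc1`: 11300 nM

All three were tested in a functional assay on MCF7 cells (Homo sapiens) for antiproliferative activity, read by sulforhodamine B assay, with a stated time of 48 h; a higher number here means a weaker inhibitor of growth, a lower number a stronger inhibitor of growth. Compound 3 gives the second highest of the three numbers. Its nearest neighbour is compound 1: the step of a 1.9-fold lower number from compound 1 to compound 3 (0.29 log units; within the scatter) lies within the scatter, so the two cannot be ranked against each other. Compound 2 stands furthest from it, and with 4100 nM compound 2 has the lowest number of the three by a margin beyond the scatter.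

Compound 4 `NS(=O)(=O)NCCC1CCN(c2cc(-c3ccc(C(F)(F)F)cc3)ncn2)CC1` has not yet been measured in this assay. It differs from compound 3 by trifluoromethyl in place of butyl on an aromatic carbon. Among the measured compounds shown here, only one measured step touches that place: a 5.3-fold lower number from compound 1 to compound 2 (0.73 log units; beyond the scatter), in which butyl likewise left an aromatic carbon, although what entered there was ethoxycarbonyl rather than trifluoromethyl. The step of a 1.9-fold lower number from compound 1 to compound 3 (0.29 log units; within the scatter) changes a different part of the molecule and says nothing about this position. On the strength of the step from compound 1 to compound 2, a lower number is expected for compound 4, probably of modest size, since the entering group is not the same one. The expected step is a 2.8-fold lower number from compound 3 to compound 4 (0.45 log units; beyond the scatter). Compound 4 is therefore estimated at 4000 nM in this assay, with a range from 1300 nM to 12000 nM.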

Compound 4, concentration for 50% growth inhibition: 15200 nM
Estimate against measurement, compound 4: 3.8-fold (0.58 log units) below; measured number outside the range, above it.
By their numbers in this assay, from the lowest: compound 2; then compounds 3, 4 and 1 (each within the scatter of the next).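

In this assay, the step from butyl to trifluoromethyl on an aromatic carbon para to a large group gives a 1.3-fold higher number from compound 3 to compound 4 (0.13 log units; within the scatter) and so cannot be ranked, which shows that butyl can leave this position, with 4 heavy atoms replaced by 4 heavy atoms, without a step beyond the scatter. Among the compounds shown here, the only earlier step at this place, a 5.3-fold lower number from compound 1 to compound 2 (0.73 log units; beyond the scatter), therefore does not hold for every group entering there, although the two steps differ both in the entering group and in the side chain on the saturated ring, so these compounds cannot separate those two differences. No measurement given here explains this result.

The compounds shown leave open whether ethoxycarbonyl would give a step beyond the scatter on the longer side chain of compound 3, and whether trifluoromethyl would do so on the shorter side chain of compound 1. They also leave open what a carboxylic acid, an amine or a nitrile on this aromatic carbon would give with either side chain.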